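Aryl Swap on the Piperazine of a Xanthine Series

This account rests on a few compounds, and the source may have more. Where it says the series, first, only, none or still open, it means among the compounds named here.

Compound 1: `CC#CCn1c(N2CCC[C@@H](N)C2)nc2c1c(=O)n(CCCN1CCN(c3ncc(OC)cn3)CC1)c(=O)n2C`, 2260 nM
Compound 2: `CC#CCn1c(N2CCC[C@@H](N)C2)nc2c1c(=O)n(CCCN1CCN(c3ncc(C)cn3)CC1)c(=O)n2C`, 2560 nM
Compound 3: `CC#CCn1c(N2CCC[C@@H](N)C2)nc2c1c(=O)n(CCCN1CCN(c3ncc(CCC)cn3)CC1)c(=O)n2C`, 1850 nM

Three compounds sharing one core were tested in a functional assay on HEK293 cells for agonist activity at Glucose-dependent insulinotropic receptor (Homo sapiens), read by a luciferase reporter; a lower number here means that less compound is needed, a higher number that more compound is needed for the effect. Compound 1 gives 2260 nM. Compound 2 gives 2560 nM, and compound 3 gives 1850 nM. The steps between them are small: a 1.1-fold higher number from compound 1 to compound 2 (0.05 log units; within the scatter), a 1.2-fold lower number from compound 1 to compound 3 (0.09 log units; within the scatter), and a 1.4-fold lower number from compound 2 to compound 3 (0.14 log units; within the scatter). Compound 3 has the lowest number of the three, but each of its gaps to the others lies within the scatter, so the three stand together.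

Compound 4, `CC#CCn1c(N2CCC[C@@H](N)C2)nc2c1c(=O)n(CCCN1CCN(c3nc(-c4ccccc4)ns3)CC1)c(=O)n2C`, carries a larger change: 3-phenyl-1,2,4-thiadiazol-5-yl in place of 5-propylpyrimidin-2-yl on an amine nitrogen in a ring. Among the compounds with values here, none of the measured steps touches the aromatic ring on that nitrogen itself; they only vary a substituent on it, and all of them stayed within the scatter. There is therefore no measured basis for a shift in either direction, and the wider ring exchange adds uncertainty. Compound 4 is expected to give about 2000 nM in this assay, within a range from 600 nM to 7000 nM, which means an expected step of a 1.1-fold higher number from compound 3 to compound 4 (0.03 log units; within the scatter).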

Compound 4, half-maximal effective concentration: 1930 nM
Estimate against measurement, compound 4: 1.0-fold (0.02 log units) above, and the stated range covers the measured number.
By their numbers in this assay, from the lowest: compounds 3, 4, 1 and 2 (each within the scatter of the next).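

Exchanging the whole aromatic group on the amine nitrogen in a ring, rather than a substituent on it, still leaves the number in this assay among those of the other compounds: a 1.0-fold higher number from compound 3 to compound 4 (0.02 log units; within the scatter), a 1.3-fold lower number from compound 2 to compound 4 (0.12 log units; within the scatter) and a 1.2-fold lower number from compound 1 to compound 4 (0.07 log units; within the scatter). This position therefore holds 3-phenyl-1,2,4-thiadiazol-5-yl, with its five-membered aromatic ring and its six-membered aromatic ring of carbon only, with no step beyond the scatter from any of the three 5-substituted pyrimidin-2-yl groups. No information at hand accounts for this result.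

As far as these compounds go, since every step here lies within the scatter, it remains open whether any group on this nitrogen can move the number further. An acetyl group, a plain benzyl group or a pyrimidin-2-yl ring bearing a carboxylic acid might answer that, as might the 1,2,4-thiadiazol-5-yl ring without its phenyl.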